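Swapping the aryl group of compound 1 for a hydroxyphenyl

The source may report more compounds than this note shows. Statements on the series, on what has been measured and on what is new or still open speak of the compounds shown alone.

Measured compounds:
compound 1 `Cn1c(-c2cccc(Cl)c2)nc2c(NC3CCCC3)ncnc21`, 6.5 nM
compound 2 `Cn1c(-c2ccccc2)nc2c(NC3CCCCC3)ncnc21`, 5.7 nM
compound 3 `CCn1c(-c2ccccc2)nc2c(NC3CCOC3)ncnc21`, 10 nM

These three compounds share a core and were tested in an assay on CHO cells for displacement of a labelled ligand from adenosine receptor A1 (Homo sapiens), read by scintillation counting, with a stated time of 3 h; on this read-out higher numbers stand for weaker inhibition and lower numbers for stronger inhibition. In this assay compound 1 gives 6.5 nM, the second highest of the three numbers; compound 2 gives 5.7 nM and compound 3 gives 10 nM, and both of these lie within the scatter of the value for compound 1, so the three cannot be ordered.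

Compound 4 `Cn1c(-c2ccc(O)cc2)nc2c(NC3CCCC3)ncnc21` has not been measured. It differs from compound 1 in one place: 4-hydroxyphenyl in place of 3-chlorophenyl on an aromatic carbon of a five-membered aromatic ring. No pair of measured compounds shows this change, so its effect in this assay is not shown. The new group brings a hydrogen-bond donor and acceptor where compound 1 has none, and the author expects a small loss, a step of a 3.1-fold higher number from compound 1 to compound 4 (0.49 log units; beyond the scatter) that may or may not pass beyond the scatter. Compound 4 is therefore estimated at 20 nM, with a range from 5 nM to 80 nM.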

Compound 4, inhibition constant: 17 nM
Estimate against measurement, compound 4: 1.2-fold (0.07 log units) above; measured number inside the range.
By their numbers in this assay, from the lowest: compounds 2, 1, 3 and 4 (each within the scatter of the next, the first and the last beyond it).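

In this assay, among these compounds, this single change gives the first reading at this aromatic carbon of the five-membered aromatic ring: 4-hydroxyphenyl in place of 3-chlorophenyl produces a 2.6-fold higher number from compound 1 to compound 4 (0.42 log units; beyond the scatter), a modest loss. The aryl group here can therefore carry a hydrogen-bond donor and acceptor at only a modest cost, with compound 4 still giving 17 nM. Nothing available accounts for the loss.

The step exchanges 3-chlorophenyl for 4-hydroxyphenyl in one move, so the compounds shown cannot separate the effect of the substituent from that of where it sits on the phenyl ring, a question that 3-hydroxyphenyl or 4-chlorophenyl would address. On these data alone, how an amine or a carboxylic acid on that phenyl ring would fare also remains open.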